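The source may report more compounds than this note shows. Statements on the series, on what has been measured and on what is new or still open speak of the compounds shown alone.

Of the compounds shown here, three have been tested in a functional assay on the whole organism for antagonist activity, with Mus musculus as the target; on this read-out lower numbers stand for an effect already at smaller amounts and higher numbers for an effect only at larger amounts of compound. Compound 1 `CC(=O)N(C)C(C)C#CCn1ccnc1` and compound 2 `CC(=O)N(C)CC#CCn1ccnc1` share a core, and compound 3 `COC(=O)N(C)CC#CCN1CCCC1` has a different core; the difference between the two cores is not broken down here.

In this assay compound 1 reaches only a limit, > 100 mg/kg. Compound 2 likewise reaches only a limit, > 100 mg/kg. Compound 3 reaches a limit as well, > 10 mg/kg. These are limits of the assay, not numbers.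

The change from compound 2 to compound 1 is methyl in place of hydrogen on a saturated chain carbon bound to an amide-type nitrogen and a triple-bonded carbon. Its size is a step that the two limits leave unreadable from compound 2 to compound 1, since both ends sit at the limit of > 100 mg/kg in this assay, at which 2 of the 3 values shown sit.

Compound 4 `CCOC(=O)N(C)CC#CCN1CCCC1` has not yet been measured. It differs from compound 3 by methyl in place of hydrogen on a saturated chain carbon bound to an oxygen next to a carbonyl group. Within the data shown here, this is the same kind of change as the one between compound 2 and compound 1, but not the same: there the carbon is bound to an amide-type nitrogen and a triple-bonded carbon, here it is bound to an oxygen next to a carbonyl group.

Compound 3 itself sits at the limit of > 10 mg/kg in this assay, at which 1 of the 3 values shown sits, so the earlier pair gives no readable size to lean on. The step from compound 3 to compound 4 in this assay is expected to be a step that the limit leaves unreadable from compound 3 to compound 4, that is, small, and the chance that compound 4 also returns only a limit is high. Compound 4 is estimated at 30 mg/kg, with a likely range from 8 mg/kg to 150 mg/kg.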

Compound 4, dose for half-maximal effect: > 100 mg/kg
Compound 4 gave a limit, no number (the forecaster's own chance of this, stated with the estimate: 75%); middle value at least 3.3-fold (0.52 log units) from the limit.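

Compound 3 and compound 4 both return only limits in this assay, not numbers, so no size can be read for the step between them. The compounds shown leave open whether methyl in place of hydrogen makes any real difference on this read-out, and at what dose, if any, each of the four compounds would reach its half-maximal effect.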